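Swapping a methylated anilide for a bromophenyl sulfonamide

This account rests on a few compounds, and the source may have more. Where it says the series, first, only, none or still open, it means among the compounds named here.

Within the data shown here, compound 1 `Cc1cccc(NS(=O)(=O)c2ccc(N3CCNC3=O)cc2)c1` gives 190 nM in a functional assay on MCF7 cells (Homo sapiens) for antiproliferative activity, read by sulforhodamine B assay, with a stated time of 48 h (on this read-out higher numbers stand for weaker inhibition and lower numbers for stronger inhibition), the second highest of the three numbers so far. Compound 3 `Cc1cc(C)cc(NS(=O)(=O)c2ccc(N3CCNC3=O)cc2)c1` gives 100 nM, and the step of a 1.9-fold lower number from compound 1 to compound 3 (0.28 log units; within the scatter) stays within the scatter. Compound 2 `O=C1NCCN1c1ccc(S(=O)(=O)Nc2ccc(F)c(F)c2)cc1` gives 620 nM; the steps of a 3.3-fold higher number from compound 1 to compound 2 (0.51 log units; beyond the scatter) and a 6.2-fold lower number from compound 2 to compound 3 (0.79 log units; beyond the scatter) both lie beyond it. Compound 4 `O=C1NCCN1c1ccc(S(=O)(=O)Nc2ccc(Br)cc2)cc1` is not yet measured. Its change from compound 1 is 4-bromophenyl in place of 3-methylphenyl on a sulfonamide nitrogen. The two measured steps in which a halogen-bearing phenyl replaced a methyl-bearing one both moved the number upward, so a modest rise is expected for compound 4, a step of a 1.7-fold higher number from compound 1 to compound 4 (0.23 log units; within the scatter). Compound 4 is therefore estimated at 320 nM, with a range from 120 nM to 850 nM.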

Compound 4, half-maximal inhibitory concentration: 240 nM
Estimate against measurement, compound 4: 1.3-fold (0.12 log units) above, and the stated range covers the measured number.
By their numbers in this assay, from the lowest: compounds 3, 1 and 4 (each within the scatter of the next, the first and the last beyond it); then compound 2.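

With a single halogen on the phenyl at the sulfonamide nitrogen, the number need not rise, as a 1.3-fold higher number from compound 1 to compound 4 (0.10 log units; within the scatter) shows, so 4-bromophenyl reads level with 3-methylphenyl. The halogen-bearing groups also separate from each other in a 2.6-fold lower number from compound 2 to compound 4 (0.41 log units; beyond the scatter) and yet 4-bromophenyl does not match 3,5-dimethylphenyl in a 2.4-fold higher number from compound 3 to compound 4 (0.38 log units; beyond the scatter). No measurement offered here accounts for these differences. The compounds shown leave open how a phenyl carrying a methoxy group, an amine or a carboxylic acid would read at this nitrogen. Going by these compounds, whether bromine elsewhere on the phenyl would give the same number also remains open.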